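Taking one methoxy group off compound 2

A few compounds are considered here, and "the series" means these few. Any claim that something is new, unique, unknown or untested is made for them only; others in the source may bear on it.

In a functional assay on ECa-109 cells (Homo sapiens) for cytotoxicity, read by MTT assay, with a stated time of 72 h (on this read-out lower numbers stand for stronger inhibition and higher numbers for weaker inhibition), compound 1 `COc1cc(C=C2C(=O)N(c3ccc(Cl)cc3)N(c3ccc(Cl)cc3)C2=O)ccc1O` gives 7100 nM. Compound 2 `COc1cccc(C=C2C(=O)N(c3ccc(Cl)cc3)N(c3ccc(Cl)cc3)C2=O)c1OC` gives 6800 nM, which lies within the scatter of compound 1, so the two stand level and neither can be ranked above the other.

Compound 3 `COc1ccccc1C=C1C(=O)N(c2ccc(Cl)cc2)N(c2ccc(Cl)cc2)C1=O` differs from compound 2 in one place: hydrogen in place of methoxy on an aromatic carbon. Put simply, 2,3-dimethoxyphenyl becomes 2-methoxyphenyl, with hydrogen in place of methoxy on an aromatic carbon.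

Among the measured compounds shown here, only one measured step bears on this change: a 1.0-fold lower number from compound 1 to compound 2 (0.02 log units; within the scatter). That step also altered the groups on the aromatic ring, and it stayed within the scatter. For the measured compounds named here, it is thin evidence, since no measured pair shows a methoxy group simply replaced by hydrogen. As far as these compounds go, no step beyond the scatter is therefore expected in this assay, and the direction remains open. The estimated step is a 1.0-fold higher number from compound 2 to compound 3 (0.01 log units; within the scatter). The expected value for compound 3 is 7000 nM, with an estimated range from 3000 nM to 16000 nM.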

Compound 3, half-maximal inhibitory concentration: 30400 nM
Beside the measured number, compound 3's estimate is 4.3-fold (0.64 log units) below it, and the stated range ends below it.
By their numbers in this assay, from the lowest: compounds 2 and 1 (each within the scatter of the next); then compound 3.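

In this assay, hydrogen in place of methoxy on an aromatic carbon gives a 4.5-fold higher number from compound 2 to compound 3 (0.65 log units; beyond the scatter), which means weaker inhibition, so this position on the ring is not indifferent to what sits there. The earlier swap between compound 1 and compound 2 changed the ring groups without moving the number beyond the scatter, but going from either compound to the 2-methoxyphenyl ring does move it, with a 4.3-fold higher number from compound 1 to compound 3 (0.63 log units; beyond the scatter) as the second measure of that loss; among these three compounds, the two with a second oxygen-bearing group on the ring stand level and the one with a single methoxy group falls behind. No measurement here accounts for why the number rises when this methoxy group leaves.

These compounds leave open whether the methoxy group itself is what counts at this position, or whether another group there, such as an amine, a fluorine atom or a longer ether chain, would hold the number at the level of compound 2. They also leave open whether taking away the other methoxy group of the 2,3-dimethoxyphenyl ring would cost as much.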